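This account rests on a few compounds, and the source may have more. Where it says the series, first, only, none or still open, it means among the compounds named here.

In an ADME assay on microsomes from liver (Homo sapiens) for pharmacokinetics, read by LC-MS, with a stated time of 60 min, tested at 1 uM (a lower number here means slower removal, a higher number faster removal of the compound), three compounds with the shared core have been measured. Compound 1 `O=C(NCc1ccc(S(=O)(=O)c2ccccc2)cc1)N1Cc2ccncc2C1` gives 7.5 mL/min/kg and compound 2 `O=C(NCc1ccc(S(=O)(=O)C2CCC(F)(F)CC2)cc1)N1Cc2ccncc2C1` gives 6 mL/min/kg in this measurement, while compound 3 `O=C(NCc1ccc(S(=O)(=O)C2CCN(C3COC3)CC2)cc1)N1Cc2ccncc2C1` gives 10 mL/min/kg and so stands within the scatter of both. The step to compound 4 `CN1CCN(S(=O)(=O)c2ccc(CNC(=O)N3Cc4ccncc4C3)cc2)CC1` puts 4-methylpiperazin-1-yl in place of 1-(oxetan-3-yl)piperidin-4-yl on a sulfonyl sulfur. Among the compounds with values here, three measured steps bear on it, all at that same place: a 1.3-fold lower number from compound 1 to compound 2 (0.10 log units; within the scatter) and a 1.3-fold higher number from compound 1 to compound 3 (0.12 log units; within the scatter) and a 1.7-fold higher number from compound 2 to compound 3 (0.22 log units; within the scatter) all lie within the scatter. Within the data shown here, no measured compound carries the entering group, so the data offer no direct precedent for it. Since none of these replacements moved this assay beyond the scatter, none is expected here either. The expected step is a 1.1-fold lower number from compound 3 to compound 4 (0.05 log units; within the scatter) and thus stays within the scatter. Compound 4 is estimated at 9 mL/min/kg with an expected span from 4.5 mL/min/kg to 20 mL/min/kg as its range.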

Compound 4, clearance: 9 mL/min/kg
Compound 4: middle estimate and measured number agree at the digits printed, within the range that was stated.
By their numbers in this assay, from the lowest: compounds 2, 1, 4 and 3 (each within the scatter of the next).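

With a 1.1-fold lower number from compound 3 to compound 4 (0.05 log units; within the scatter) and a 1.5-fold higher number from compound 2 to compound 4 (0.18 log units; within the scatter) and a 1.2-fold higher number from compound 1 to compound 4 (0.08 log units; within the scatter) all inside the scatter, 4-methylpiperazin-1-yl joins the earlier groups on the sulfonyl sulfur as a fourth that leaves this assay without a step beyond the scatter. The change also gives up the four-membered non-aromatic ring of 1-(oxetan-3-yl)piperidin-4-yl, and that loss leaves the number within the scatter too, so across these four compounds no group at this place stands apart from the others. No available evidence says why the numbers stay so close. The compounds shown leave open whether a carboxylic acid or a longer alkyl chain on the sulfonyl sulfur would give a step beyond the scatter. They also leave open whether a change elsewhere on the shared core would do so.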